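Trifluoromethyl for iodo on the aryl triazole

The source may hold more compounds than are shown below. What is called first, only, known or untested is meant among the compounds shown, and "the series" means these compounds.

Measured compounds:
compound 1 `O=C(Nc1cccc(OCc2cn(-c3ccccc3Br)nn2)c1)Nc1ccc(Cl)c(C(F)(F)F)c1` gives 2810 nM
compound 2 `O=C(Nc1cccc(OCc2cn(-c3ccc(I)cc3)nn2)c1)Nc1ccc(Cl)c(C(F)(F)F)c1` gives 2690 nM

Both compounds were tested in a functional assay on HepG2 cells (Homo sapiens) for inhibition, read by MTT assay, with a stated time of 72 h; on this read-out higher numbers stand for weaker inhibition and lower numbers for stronger inhibition. Compound 1 gives 2810 nM and compound 2 gives 2690 nM. The step of a 1.0-fold lower number from compound 1 to compound 2 (0.02 log units; within the scatter) shows that exchanging one halogenated phenyl on the triazole nitrogen for another left the read-out unchanged. Compound 2 therefore stands level with compound 1; on the numbers shown, nothing separates them.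

Compound 3 `O=C(Nc1cccc(OCc2cn(-c3ccc(C(F)(F)F)cc3)nn2)c1)Nc1ccc(Cl)c(C(F)(F)F)c1` has not yet been measured. It differs from compound 2 by trifluoromethyl in place of iodo on an aromatic carbon. Going by the values given here, the only measured step that bears on this region is a 1.0-fold lower number from compound 1 to compound 2 (0.02 log units; within the scatter), which was within the scatter, and that step changed both the halogen and its position on the phenyl. On that basis no step beyond the scatter is expected in this assay for the exchange of iodo for trifluoromethyl at the same position.

Compound 3 is estimated at 2700 nM, with a range of 1300 nM to 5600 nM, which means an expected step of a 1.0-fold higher number from compound 2 to compound 3 (0.00 log units; within the scatter).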

Compound 3, half-maximal inhibitory concentration: 1800 nM
For compound 3 the middle estimate is 1.5-fold (0.18 log units) above the measured one, within the range that was stated.
By their numbers in this assay, from the lowest: compounds 3, 2 and 1 (each within the scatter of the next).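

In this assay the exchange of iodo for trifluoromethyl, one heavy atom leaving and four entering, gives a 1.5-fold lower number from compound 2 to compound 3 (0.17 log units; within the scatter) and so stays within the scatter, which shows that this place on the phenyl accepts a group other than a halogen without a step that can be told from repeat variation. The comparison with the 2-bromophenyl compound gives a 1.6-fold lower number from compound 1 to compound 3 (0.19 log units; within the scatter) in this assay, so all three aryl groups shown on the triazole nitrogen read alike, and the earlier pair of halogenated compounds could not show that this extends beyond halogens. No supporting measurement accompanies these numbers, and nothing can be said about why the read-out stays level.

The compounds shown leave open whether the same level holds when an amine, a carboxylic acid or a longer chain takes the place of the trifluoromethyl. Going by these compounds alone, they also leave open what position alone contributes, for the steps from compound 1 change the group and its place together, and no pair here separates the two.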